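This account rests on a few compounds, and the source may have more. Where it says the series, first, only, none or still open, it means among the compounds named here.

Among the three measured compounds, compound 3 `CC[C@@H](C)[C@H](NC(=O)c1ccc(C(CC)(CC)c2ccc(OCC(=O)C(C)(C)C)c(C)c2)n1CC)C(=O)O` stands lowest in an assay on HL-60 cells for agonist activity at vitamin D3 receptor (Homo sapiens), read by microscopy, with a stated time of 96 h (on this read-out lower numbers stand for an effect already at smaller amounts and higher numbers for an effect only at larger amounts of compound), with 10 nM. Compound 1 `CCN(CC)CCNC(=O)c1ccc(C(CC)(CC)c2ccc(OCC(=O)C(C)(C)C)c(C)c2)n1CC` gives 91 nM and compound 2 `C#CCNC(=O)c1ccc(C(CC)(CC)c2ccc(OCC(=O)C(C)(C)C)c(C)c2)n1CC` gives 2200 nM; the steps of a 9.1-fold lower number from compound 1 to compound 3 (0.96 log units; beyond the scatter) and a 220-fold lower number from compound 2 to compound 3 (2.34 log units; beyond the scatter) both run toward the amide carrying a carboxylic acid. Compound 4 `CCn1c(C(=O)N(C)CC(=O)O)ccc1C(CC)(CC)c1ccc(OCC(=O)C(C)(C)C)c(C)c1` is not yet measured; it differs from compound 3 by (carboxymethyl)(methyl)amino in place of (1-carboxy-2-methylbutyl)amino on a carbonyl carbon, keeping a carboxylic acid but giving up the branched chain of the 1-carboxy-2-methylbutyl group and the amide hydrogen. Going by the values given here, no measured step isolates either of those changes, so the bearing of the measured steps is only indirect. Compound 4 is expected to stay nearer compound 3 than compound 2, with a modest rise, a 4.0-fold higher number from compound 3 to compound 4 (0.60 log units; beyond the scatter). The estimate for compound 4 is 40 nM, within 10 nM to 200 nM.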

Compound 4, half-maximal effective concentration: 1390 nM
The estimate for compound 4 lay 35-fold (1.54 log units) below the measured number; the measured number lies above the stated range.
By their numbers in this assay, from the lowest: compound 3; then compound 1; then compounds 4 and 2 (each within the scatter of the next).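

In this assay a carboxylic acid on this carbonyl carbon does not by itself keep the number low: (carboxymethyl)(methyl)amino in place of (1-carboxy-2-methylbutyl)amino gives (a 140-fold higher number from compound 3 to compound 4 (2.14 log units; beyond the scatter)). The same group in place of propargylamino gives (a 1.6-fold lower number from compound 2 to compound 4 (0.20 log units; within the scatter)), and in place of (2-(diethylamino)ethyl)amino it gives (a 15-fold higher number from compound 1 to compound 4 (1.18 log units; beyond the scatter)). No measurement shown accounts for these steps.

From the compounds shown here alone, the change removes both the branched chain and the amide hydrogen, and which of these matters stays open. (Carboxymethyl)amino, which keeps the amide hydrogen, and (1-carboxy-2-methylbutyl)(methyl)amino, which keeps the branched chain, would separate them.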